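The compounds below may be only part of what the source reports. "The series", "measured", "known", "first", "only" and "open" are said of these compounds alone.

Compound 1 `C[C@H](Nc1nc(Cl)nc(NC(C)(C)C)n1)c1ccccc1` gives 3310 nM in an ADME assay on the whole organism for inhibition, with Oryza sativa as the target, with a stated time of 4 days; on this read-out higher numbers stand for weaker inhibition and lower numbers for stronger inhibition.
Compound 2 `CC[C@H](C)Nc1nc(Cl)nc(N[C@@H](C)c2ccccc2)n1` gives 6920 nM in this assay.
Compound 3 `CC(C)Nc1nc(Cl)nc(N[C@@H](C)c2ccccc2)n1` gives 23400 nM in this assay.

Of these three, compound 3 has the highest number, so it is the weakest inhibitor of rice growth among them: compound 2 sits nearest, with a 3.4-fold higher number from compound 2 to compound 3 (0.53 log units; beyond the scatter) separating them, and compound 1 furthest, with a 7.1-fold higher number from compound 1 to compound 3 (0.85 log units; beyond the scatter).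

Among the compounds with values here, compound 4 `CCCN(CCC)c1nc(Cl)nc(N[C@@H](C)c2ccccc2)n1` keeps the core of compound 3 and changes only one group: dipropylamino in place of isopropylamino on an aromatic carbon.

The measured steps all alter the alkyl group on that same nitrogen. Removing one carbon gave a 2.1-fold higher number from compound 1 to compound 2 (0.32 log units; beyond the scatter), a 7.1-fold higher number from compound 1 to compound 3 (0.85 log units; beyond the scatter) and a 3.4-fold higher number from compound 2 to compound 3 (0.53 log units; beyond the scatter); in each case a smaller group meant a higher number. Within the data shown here, compound 4 adds carbons, which by that trend points toward a lower number, but it also removes the hydrogen-bond donor on that nitrogen, and no measured step shows what that does. The expectation is therefore uncertain: for compound 4 a step of about a 1.1-fold higher number from compound 3 to compound 4 (0.03 log units; within the scatter) is estimated, with a wide range. Compound 4 is expected to give around 25000 nM, estimated to lie between 6000 nM and 100000 nM.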

Compound 4, half-maximal inhibitory concentration: 331 nM
Compound 4: middle estimate off by 76-fold (1.88 log units), on the high side; the measured number lies below the stated range.
By their numbers in this assay, from the lowest: compound 4; then compound 1; then compound 2; then compound 3.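

Swapping isopropylamino for dipropylamino on this aromatic carbon, between two ring nitrogen atoms, gives by far the largest change in the set (a 71-fold lower number from compound 3 to compound 4 (1.85 log units; beyond the scatter)), and the same group also beats the other two amino groups (a 21-fold lower number from compound 2 to compound 4 (1.32 log units; beyond the scatter); a 10-fold lower number from compound 1 to compound 4 (1.00 log units; beyond the scatter)). The earlier compounds shown here all kept a hydrogen-bond donor on this nitrogen, whereas compound 4 shows that the position accepts a group with 0 hydrogen-bond donors and still gives the lowest number of the four. Nothing measured here explains why this change has so large an effect.

The step adds carbon and removes the amino hydrogen at once, so the two changes cannot be told apart. Propylamino, which keeps that hydrogen, and diethylamino, with its shorter chains, would be needed to separate them, and how dibutylamino would behave also remains open.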